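Notes on the group on the aromatic oxygen

The source may report more compounds than this note shows. Statements on the series, on what has been measured and on what is new or still open speak of the compounds shown alone.

Two compounds of this series have numbers in an assay on cells for antagonist activity at transient receptor potential cation channel subfamily V member 1 (Homo sapiens), read by FLIPR and calcium flux, with a stated time of 6 min; on this read-out lower numbers stand for stronger inhibition and higher numbers for weaker inhibition. Compound 1 `CCCOc1nc(C(C)(C)C)ccc1CNC(=O)C(C)c1ccc(NS(C)(=O)=O)c(F)c1` gives 1.7 nM. Within the data shown here, compound 2 `CC(C(=O)NCc1ccc(C(C)(C)C)nc1OC1CCCCC1)c1ccc(NS(C)(=O)=O)c(F)c1` gives 2.5 nM, the higher of the two numbers, but the only measured step, a 1.5-fold higher number from compound 1 to compound 2 (0.17 log units; within the scatter), is within the scatter, so the two compounds are not separated on this read-out.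

Compound 3 `CC(C(=O)NCc1ccc(C(C)(C)C)nc1OCc1ccc(F)cc1)c1ccc(NS(C)(=O)=O)c(F)c1` differs from compound 2 by 4-fluorobenzyl in place of cyclohexyl on an oxygen on an aromatic ring. Among the measured compounds shown here, the one step that bears on this position, a 1.5-fold higher number from compound 1 to compound 2 (0.17 log units; within the scatter), concerns cyclohexyl in place of propyl on the same oxygen and was within the scatter. For the measured compounds named here, no measured step covers an aromatic group on this oxygen, so the present change goes beyond what the two measured compounds show; the only guidance is that the two groups tried so far gave numbers within the scatter of each other.

For compound 3 the step of a 1.2-fold higher number from compound 2 to compound 3 (0.08 log units; within the scatter) is therefore expected to lie within the scatter, with the range widened for the untested aromatic group. The estimate for compound 3 is 3 nM, between 1 nM and 10 nM.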

Compound 3, inhibition constant: 0.8 nM
Estimate against measurement, compound 3: 3.8-fold (0.57 log units) above; the whole stated range lies above it.
By their numbers in this assay, from the lowest: compound 3; then compounds 1 and 2 (each within the scatter of the next).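

Notes on the result

In this assay, the group on the oxygen now separates the compounds: a 3.1-fold lower number from compound 2 to compound 3 (0.49 log units; beyond the scatter) and a 2.1-fold lower number from compound 1 to compound 3 (0.33 log units; beyond the scatter), so 4-fluorobenzyl stands apart from both cyclohexyl and propyl, which could not be told apart from each other. Compound 3 is therefore the strongest of the three on this read-out, although both steps are modest, and this position is shown to tolerate an aromatic ring on the carbon bound to the oxygen with no loss on this read-out. No measured information is available to explain these steps.

The change from cyclohexyl introduces an aromatic ring and a fluorine together, so the compounds shown do not tell which of the two goes with the lower number; plain benzyl would be the direct comparison for 4-fluorobenzyl. On these data alone, it also remains open how the number would respond to a longer chain between the oxygen and the ring, as in 2-phenylethyl, or to an amine on the group in place of the fluorine.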